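The compounds below may be only part of what the source reports. "The series", "measured", "known", "first", "only" and "open" are said of these compounds alone.

Measured so far:
- compound 1 `CCCC[C@@H](/C=C\[C@@H]1OC(=O)C=C[C@@H]1O)OC(C)=O`: 2.2 ug/mL
- compound 2 `CCCC[C@@H](/C=C\[C@@H]1OC(=O)C=C[C@@H]1OC(C)=O)OC(C)=O`: 0.9 ug/mL

Compound 2 holds the lowest of the two numbers in a functional assay on P388 cells (Mus musculus) for cytotoxicity, read by sulforhodamine B assay, with a stated time of 48 h; on this read-out lower numbers stand for an effect already at smaller amounts and higher numbers for an effect only at larger amounts of compound; its nearest neighbour is compound 1, whose value in this assay is 2.2 ug/mL. Compound 3 `CCCC[C@H](O)/C=C\[C@@H]1OC(=O)C=C[C@@H]1OC(C)=O` is unmeasured; relative to compound 2 the change is hydrogen in place of acetyl on an oxygen on a saturated carbon, leaving the acetyl on the ring oxygen in place.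

Within the data shown here, the only measured step that bears on this is a 2.4-fold lower number from compound 1 to compound 2 (0.39 log units; beyond the scatter), which added an acetyl on an oxygen on a saturated carbon, though at a different position from the one now concerned. Removing an acetyl here is the reverse kind of change at another site, so the step from compound 2 to compound 3 is expected to run in the opposite direction, a modest rise in the number, roughly a 2.0-fold higher number from compound 2 to compound 3 (0.30 log units; within the scatter). Compound 3 is accordingly estimated at 1.8 ug/mL, with a range of 0.7 ug/mL to 4.5 ug/mL.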

Compound 3, concentration for half-maximal effect: 0.1 ug/mL
Estimate against measurement, compound 3: 18-fold (1.26 log units) above; the measured number lies below the stated range.
By their numbers in this assay, from the lowest: compound 3; then compound 2; then compound 1.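

In this assay, acetoxy to hydroxy on the saturated carbon of the chain gives a 9.0-fold lower number from compound 2 to compound 3 (0.95 log units; beyond the scatter) and is beyond the scatter, so here the free hydroxy carries the lower number while the acetyl on the ring oxygen stays in place. The earlier step, a 2.4-fold lower number from compound 1 to compound 2 (0.39 log units; beyond the scatter) on adding that ring acetyl, also lowered the number, so acetyl has opposite effects at these positions and a step at one oxygen does not predict the other. Nothing measured here explains why the positions differ.

Going by these compounds, it remains open whether the lower number depends on the free hydroxy itself or only on losing the acetyl, a question that a methyl ether or an amine on this carbon would address. On these data alone, whether a butyryl ester on the ring oxygen would follow the acetyl step also remains open.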